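Chloro to methoxy on the aryl-thiazole ketone side chain

The source may hold more compounds than are shown below. What is called first, only, known or untested is meant among the compounds shown, and "the series" means these compounds.

Measured so far:
compound 1, `Cc1nc(-c2ccc(Cl)cc2)sc1C(=O)CSc1nc(-c2ccc(Cl)c(Cl)c2)c(C#N)c(=O)[nH]1`, 97.1%
compound 2, `Cc1nc(-c2ccc(Cl)cc2)sc1C(=O)CSc1nc(N)c(C#N)c(-c2ccc(Cl)cc2)n1`, 37.3%

In a functional assay on U-87MG ATCC cells for antiproliferative activity against U-87 MG (Homo sapiens), read by MTT assay, with a stated time of 48 h, tested at 10 uM (a lower number here means a stronger effect, a higher number a weaker effect of the compound at the concentration tested), compound 1 gives 97.1%, the highest of the two numbers measured, which here means the weaker effect at the concentration tested. The nearest neighbour, compound 2, gives 37.3% in this assay, a lower number by a margin that lies beyond the usual scatter. For the measured compounds named here, compound 2 differs from compound 1 in more than one place, so no single step between the two is counted.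

The step under consideration leads from compound 1 to compound 3, `COc1ccc(-c2nc(C)c(C(=O)CSc3nc(-c4ccc(Cl)c(Cl)c4)c(C#N)c(=O)[nH]3)s2)cc1`, not yet measured in this assay. The change is methoxy in place of chloro on an aromatic carbon, at the place described there, with the rest of the shared core kept. Nothing measured here isolates this change, so no step size is known from data. A small step is expected, if any, within the scatter or slightly toward a lower number: the estimate for a number 7.1 percentage points lower from compound 1 to compound 3 (within the scatter) is a modest move downward at most.

Compound 3 is therefore estimated at 90% in this assay, with a range from 65% to 105%.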

Compound 3, a percentage reported as activity, at one concentration (the size of the read-out at that concentration, not a potency): 88.6%
Beside the measured number, compound 3's estimate is 1.4 percentage points above it; measured number inside the range.
By their numbers in this assay, from the lowest: compound 2; then compounds 3 and 1 (each within the scatter of the next).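

In this assay, for the compounds shown here, the exchange of 4-chlorophenyl for 4-methoxyphenyl, on an aromatic carbon para to a large group, gives a number 8.5 percentage points lower from compound 1 to compound 3 (within the scatter), and this is the only step that isolates a single change. At this position, methoxy, which brings a hydrogen-bond acceptor that chloro lacks, can therefore replace chloro with the shared core kept, and no change beyond the scatter appears: compound 3 gives 88.6% and stays level with compound 1 in this assay. The data shown offer no measurement that explains this outcome.

From the compounds shown here alone, whether an amine, a carboxylic acid or a longer chain such as ethoxy at the same place would move the number beyond the scatter remains open. Also open, going by these compounds, is whether the exchange of chloro for methoxy would read the same on the core of compound 2, which gives 37.3% with the chloro side chain.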